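Swapping Halogens on the Outer Ring of a Thiourea

The source may hold more compounds than are shown below. What is called first, only, known or untested is meant among the compounds shown, and "the series" means these compounds.

Of the compounds shown here, three sharing one core have been tested in a functional assay on MDA-MB-231 cells (Homo sapiens) for antiproliferative activity, read by MTT assay; on this read-out higher numbers stand for weaker inhibition and lower numbers for stronger inhibition. Compound 1 `CNC(=O)c1ccc(Oc2cccc(NC(=S)Nc3ccc(F)c(C(F)(F)F)c3)c2)nc1` gives 13300 nM in this assay. Compound 2 `CNC(=O)c1ccc(Oc2cccc(NC(=S)Nc3ccc(C)c(C)c3)c2)nc1` gives 38600 nM in this assay. Compound 3 `CNC(=O)c1ccc(Oc2cccc(NC(=S)Nc3ccc(Cl)cc3Cl)c2)nc1` gives 20700 nM in this assay, which places it second highest among the three numbers, with compound 1 nearest and compound 2 furthest, both within the scatter of it.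

Compound 4 `CNC(=O)c1ccc(Oc2cccc(NC(=S)Nc3ccc(F)c(F)c3)c2)nc1` has not yet been measured. It differs from compound 3 in one place: 3,4-difluorophenyl in place of 2,4-dichlorophenyl on an amide-type nitrogen.

Within the data shown here, the only measured step that bears on this change is the earlier swap of the outer ring, a 1.9-fold lower number from compound 2 to compound 3 (0.27 log units; within the scatter), which stayed within the scatter. The spread between compound 1 and compound 3 also stays within the scatter. On this basis the step in this assay is expected to be small, with no clear direction.

Compound 4 is therefore estimated at 20000 nM in this assay, between 7000 nM and 60000 nM, an expected step of a 1.0-fold lower number from compound 3 to compound 4 (0.01 log units; within the scatter).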

Compound 4, half-maximal inhibitory concentration: 69300 nM
Compound 4: middle estimate off by 3.5-fold (0.54 log units), on the low side, outside the stated range (above it).
By their numbers in this assay, from the lowest: compounds 1, 3, 2 and 4 (each within the scatter of the next, the first and the last beyond it).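

Among these compounds, the outer ring on the thiourea nitrogen can shift the number in this assay beyond the scatter: 3,4-difluorophenyl in place of 2,4-dichlorophenyl gives a 3.3-fold higher number from compound 3 to compound 4 (0.52 log units; beyond the scatter) and is the first step here to pass that line, of the two now read between these rings. Fluoro in place of trifluoromethyl on an aromatic carbon gives a 5.2-fold higher number from compound 1 to compound 4 (0.72 log units; beyond the scatter) and also lies beyond the scatter. Not every ring swap registers, though: 3,4-difluorophenyl in place of 3,4-dimethylphenyl gives a 1.8-fold higher number from compound 2 to compound 4 (0.25 log units; within the scatter) and stays within the scatter.

From the compounds shown here alone, compound 3 and compound 4 differ in both the halogen and its printed ring numbering, so the effect of each alone stays open, and a 3,4-dichlorophenyl or a methoxy-bearing phenyl ring on this nitrogen could help separate them. Nothing shown here gives any measured explanation for these steps.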